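The source may report more compounds than this note shows. Statements on the series, on what has been measured and on what is new or still open speak of the compounds shown alone.

Working notes on the series, read in a functional assay on DU-145 cells (Homo sapiens) for cytotoxicity, read by trypan blue exclusion, with a stated time of 96 h; a higher number here means a weaker inhibitor, a lower number a stronger inhibitor. Compound 1 (`COc1ccc(NS(=O)(=O)/C=C/c2c(OC)cc(OC)cc2OC)cc1`) gives 200 nM, compound 2 (`COc1cc(OC)c(/C=C/S(=O)(=O)Nc2ccc(OC)c(F)c2)c(OC)c1`) gives 200 nM and compound 3 (`COC(=O)CNc1cc(NS(=O)(=O)/C=C/c2c(OC)cc(OC)cc2OC)ccc1OC`) gives 350 nM. These three numbers lie within the scatter of each other, so compound 3 stands level with the other two and no order can be read among them.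

The next structure is compound 4 (`COC(=O)C(C)Nc1cc(NS(=O)(=O)/C=C/c2c(OC)cc(OC)cc2OC)ccc1OC`). Its difference from compound 3 is methyl in place of hydrogen on a saturated chain carbon bound to a carbonyl carbon and a nitrogen on an aromatic ring.

Within the data shown here, no measured step alters this carbon, so the evidence is indirect. Adding the whole ((methoxycarbonyl)methyl)amino group gave a 1.8-fold higher number from compound 1 to compound 3 (0.24 log units; within the scatter), and putting it in place of fluoro gave a 1.8-fold higher number from compound 2 to compound 3 (0.24 log units; within the scatter). Fluoro in place of hydrogen gave no change at the digits printed from compound 1 to compound 2 (within the scatter). All three steps stay within the scatter, which suggests that this part of the series tolerates change in this assay, though the data are few. A single added methyl is therefore expected to produce no step beyond the scatter. The expected step is no change at the digits printed from compound 3 to compound 4 (within the scatter). For compound 4 the estimated value is 350 nM, with an expected range of 150 nM to 900 nM.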

Compound 4, half-maximal inhibitory concentration: 100 nM
Estimate against measurement, compound 4: 3.5-fold (0.54 log units) above, outside the stated range (below it).
By their numbers in this assay, from the lowest: compounds 4, 1, 2 and 3 (each within the scatter of the next, the first and the last beyond it).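

In this assay the saturated chain carbon bound to a carbonyl carbon and a nitrogen on an aromatic ring turns out to be a place that responds to change: methyl in place of hydrogen there gives a 3.5-fold lower number from compound 3 to compound 4 (0.54 log units; beyond the scatter), the only step among these compounds that lies beyond the scatter, and it comes from one added carbon. The (1-(methoxycarbonyl)ethyl)amino group itself stays within the scatter of the simpler compounds, with a 2.0-fold lower number from compound 1 to compound 4 (0.30 log units; within the scatter) and a 2.0-fold lower number from compound 2 to compound 4 (0.30 log units; within the scatter), so the methyl separates compound 4 from compound 3 but not from compound 1 or compound 2. Nothing available here accounts for the step at this carbon.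

Still open, going by these compounds, is whether an ethyl or an isopropyl group at this carbon would carry the step further, and whether a carboxylic acid in place of the methyl ester would keep it. Compound 4 is also drawn without a stated configuration at this carbon, so its two mirror-image forms cannot be told apart here.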